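This account rests on a few compounds, and the source may have more. Where it says the series, first, only, none or still open, it means among the compounds named here.

Compound 1 `Fc1ccccc1N1CCN(Cn2nc(-c3ccc4c(c3)OCCO4)oc2=S)CC1` gives 37800 nM in a functional assay on SW 1116 cells (Homo sapiens) for antiproliferative activity, read by MTT assay, with a stated time of 48 h; a higher number here means a weaker inhibitor, a lower number a stronger inhibitor.
Compound 2 `S=c1oc(-c2ccc3c(c2)OCCO3)nn1CN1CCN(c2cccc(Cl)c2)CC1` gives only a limit of this assay, > 50000 nM.

Compound 2 thus stands at the weak end of what was measured, with one of the two values sitting at the limit of > 50000 nM in this assay, at which 1 of the 2 values shown sits. Among the measured compounds shown here, the only measured step, an at least 1.3-fold higher number from compound 1 to compound 2 (0.12 log units; that floor lies within the scatter), is small and its floor lies within the scatter. Compound 3 `COc1ccccc1N1CCN(Cn2nc(-c3ccc4c(c3)OCCO4)oc2=S)CC1` differs from compound 2 by 2-methoxyphenyl in place of 3-chlorophenyl on an amine nitrogen in a ring. For the measured compounds named here, that single step is the only guide for this change, and it points to little movement. Compound 3 is therefore expected to give 45000 nM (range 15000 nM to 150000 nM), an expected step of an at least 1.1-fold lower number from compound 2 to compound 3 (0.04 log units; that floor lies within the scatter) that stays within the scatter, with a real chance that only a limit is reported again.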

Compound 3, half-maximal inhibitory concentration: 16900 nM
Estimate against measurement, compound 3: 2.7-fold (0.43 log units) above; low and high end bracket the measured number.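

In this assay, among the compounds shown here, 2-methoxyphenyl on the amine nitrogen in the ring brings the first steps beyond the scatter: an at least 2.9-fold lower number from compound 2 to compound 3 (0.47 log units; beyond the scatter), and a 2.2-fold lower number from compound 1 to compound 3 (0.35 log units; beyond the scatter). The second step joins two measured numbers, so methoxy in place of fluoro on an aromatic carbon is enough on its own to lower the number. The first step is only a floor, since compound 2 gives a limit: the limit of > 50000 nM in this assay, at which 1 of the 3 values shown sits.

As far as these compounds go, whether a longer chain such as ethoxy, or an amine, on this phenyl ring would lower the number further remains open.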